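The source may hold more compounds than are shown below. What is called first, only, known or untested is meant among the compounds shown, and "the series" means these compounds.

Of the compounds shown here, three of one series have been measured in an assay on isolated protein for inhibition of STE20-like serine/threonine-protein kinase (Homo sapiens), read by thermal shift assay, tested at 10 uM; a lower number here means that the compound stabilises the target less, a higher number that the compound stabilises the target more against heat. Compound 1 `CCOc1ccc(NC(=O)Nc2cc(C(C)(C)C)nn2-c2ccccc2)cc1` gives 1.1 degrees C in this assay. Compound 2 `Cc1ccc(S(=O)(=O)NC(=O)Nc2cc(C(C)(C)C)nn2-c2ccccc2)cc1` gives -0.3 degrees C in this assay. Compound 3 `Cc1ccc(-n2nc(C(C)(C)C)cc2NC(=O)Nc2cc(C(F)(F)F)cc(C(F)(F)F)c2)cc1` gives 0 degrees C in this assay, the second highest of the three numbers; its nearest neighbour is compound 2, whose number lies lower by an amount within the scatter, while compound 1 lies higher by an amount beyond the scatter.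

Compound 4 `CC(C)(C)c1cc(NC(=O)Nc2cc(C(F)(F)F)cc(C(F)(F)F)c2)n(-c2ccc(F)cc2)n1` has not yet been measured. It differs from compound 3 in one place: fluoro in place of methyl on an aromatic carbon, a fluoro in place of methyl on an aromatic carbon, so that the 4-methylphenyl of compound 3 reads as 4-fluorophenyl in compound 4. Among the measured compounds shown here, no pair of measured compounds shows a step of this kind, so its size is open. The step of a number 0.10 degrees C higher from compound 3 to compound 4 (within the scatter) is expected to stay within the scatter, in no clear direction. Because compound 3 gives 0 degrees C and the three measured numbers sit close together, compound 4 is expected to give about 0.1 degrees C in this assay, with a range from -0.9 degrees C to 1.1 degrees C.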

Compound 4, shift of the target's melting temperature: 0.5 degrees C
Compound 4: the middle estimate sits 0.40 degrees C below what was measured; the measured number falls inside the stated range.
By their numbers in this assay, from the lowest: compounds 2, 3, 4 and 1 (each within the scatter of the next, the first and the last beyond it).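

Among the compounds shown here, this is the first step that can be read at one place: in this assay, going from 4-methylphenyl to 4-fluorophenyl, with fluoro in place of methyl on an aromatic carbon para to a large group, gives a number 0.50 degrees C higher from compound 3 to compound 4 (within the scatter). The earlier compounds shown here offered no such comparison, and this one shows that the two groups cannot be told apart at this position, at least with the rest of compound 3 kept unchanged. Nothing measured here offers an explanation for this result.

The compounds shown leave open whether an amine, a carboxylic acid or a methoxy group at this position would give a step beyond the scatter. They also leave open whether the exchange of methyl for fluoro would read the same on the core of compound 1.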